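A Step Away from the Dihydroxypropoxycarbonyl Group

This account rests on a few compounds, and the source may have more. Where it says the series, first, only, none or still open, it means among the compounds named here.

Measured in a physicochemical assay for lipophilicity, read by HPLC, measured as chromatographic lipophilicity; a higher number here means a more lipophilic compound, a lower number a more polar compound:
- compound 1 `CCC/N=C1\S/C(=C\c2ccc(C(=O)NCCO)cc2)C(=O)N1c1ccccc1C`: 2.3
- compound 2 `CCC/N=C1\S/C(=C\c2ccc(C(=O)OCC(O)CO)cc2)C(=O)N1c1ccccc1O`: 1.8

Compound 2, at 1.8, stands lowest of the two, and compound 1, at 2.3, lies above it by a gap beyond the scatter. Compound 3 `CCC/N=C1\S/C(=C\c2ccc(CCC(=O)OC)cc2)C(=O)N1c1ccccc1O` differs from compound 2 in one place, on an aromatic carbon para to a large group: 2-(methoxycarbonyl)ethyl in place of (2,3-dihydroxypropoxy)carbonyl (2-(methoxycarbonyl)ethyl in place of (2,3-dihydroxypropoxy)carbonyl on an aromatic carbon). For the measured compounds named here, no measured pair shows this change, so the expectation rests on the structural change alone: a rise beyond the scatter in this assay. The expected step is a number 1.10 log units higher from compound 2 to compound 3 (beyond the scatter). For compound 3 the estimated value is 2.9, within a range of 2.4 to 3.5.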

Compound 3, distribution coefficient: 3.5
Estimate against measurement, compound 3: 0.60 log units below; low and high end bracket the measured number.
By their numbers in this assay, from the lowest: compound 2; then compound 1; then compound 3.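

Measured in this assay the exchange of (2,3-dihydroxypropoxy)carbonyl for 2-(methoxycarbonyl)ethyl on this aromatic carbon gives a number 1.70 log units higher from compound 2 to compound 3 (beyond the scatter) and is the only single-place step shown. It is a large step, so the read-out is far from indifferent to the group held at this position. No evidence at hand ties the step to any one feature of the exchange.

From the compounds shown here alone, how a carboxylic acid or an amine at the end of this chain would read remains open, as does the effect of a longer chain at the same carbon.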